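The source may hold more compounds than are shown below. What is called first, only, known or untested is meant among the compounds shown, and "the series" means these compounds.

Compound 1 `O=C(Nc1ccc(-c2cscn2)cc1)C1CCCN(Cc2cccc(F)c2)C1`: 5000 nM
Compound 2 `O=C(Nc1ccc(-c2nccs2)cc1)C1CCCN(Cc2ccc(F)c(F)c2)C1`: 800 nM

In a functional assay on A-375 cells (Homo sapiens) for activation, with a stated time of 3 days (a lower number here means that less compound is needed, a higher number that more compound is needed for the effect), compound 2 gives 800 nM, the lower of the two numbers and clear of the scatter from the value of compound 1, 5000 nM. Compound 3 `O=C(Nc1ccc(-c2cccs2)cc1)C1CCCN(Cc2ccc(F)c(F)c2)C1` keeps the rest of compound 2 and carries thiophen-2-yl in place of 1,3-thiazol-2-yl on an aromatic carbon. Among the measured compounds shown here, no measured pair shows this exchange, so the expectation remains cautious. The expected step of a 1.2-fold lower number from compound 2 to compound 3 (0.09 log units; within the scatter) is small and does not go beyond the scatter. For compound 3 the estimated value is 650 nM, with an expected range of 200 nM to 2200 nM.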

Compound 3, half-maximal effective concentration: 530 nM
The estimate for compound 3 lay 1.2-fold (0.09 log units) above the measured number; low and high end bracket the measured number.
By their numbers in this assay, from the lowest: compounds 3 and 2 (each within the scatter of the next); then compound 1.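

Read in this assay, thiophen-2-yl in place of 1,3-thiazol-2-yl on an aromatic carbon, para to a large group, gives a 1.5-fold lower number from compound 2 to compound 3 (0.18 log units; within the scatter) and so stays within the scatter. In this one pair, the position therefore tolerates the loss of the ring nitrogen and of one counted hydrogen-bond acceptor with no clear change in the number. Nothing measured here explains this result.

Going by these compounds, whether an amine or a carboxylic acid at this position would also stay within the scatter of compound 2 remains open. So does whether the same exchange would read alike on another compound.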